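Swapping the aryl on the triazole of two terpenoid cores

The source may hold more compounds than are shown below. What is called first, only, known or untested is meant among the compounds shown, and "the series" means these compounds.

Compound 1 `CC(C)=CCC/C(C)=C/CC/C(C)=C/CC[C@@H]1[C@@]2(C)CC/C(=N\OCc3cn(-c4ccc(F)c(Cl)c4)nn3)C(C)(C)[C@@H]2CC[C@@]1(C)O` and compound 2 `CC(C)=CCC/C(C)=C/CC/C(C)=C/CC[C@@H]1[C@@]2(C)CC/C(=N\OCc3cn(-c4c(Cl)cc([N+](=O)[O-])cc4Cl)nn3)C(C)(C)[C@@H]2CC[C@@]1(C)O` share one core and differ only in the change (2,6-dichloro-4-nitrophenyl in place of 3-chloro-4-fluorophenyl on an aromatic nitrogen). In a functional assay on HeLa cells (Homo sapiens) for cytotoxicity, read by MTT assay, with a stated time of 48 h (on this read-out lower numbers stand for stronger inhibition and higher numbers for weaker inhibition), compound 1 gives 20100 nM, and compound 2 gives 23000 nM, so that a 1.1-fold higher number from compound 1 to compound 2 (0.06 log units; within the scatter). Compound 3 `CC(C)=CCC/C(C)=C/CC/C(C)=C/CC[C@@H]1[C@@]2(C)C/C(=C\c3ccc(OCc4cn(-c5ccc(F)c(Cl)c5)nn4)cc3)C(=O)C(C)(C)[C@@H]2CC[C@@]1(C)O` is built on a different core; how the two cores differ is not broken down here. In this assay compound 3 gives 43000 nM. Compound 4 `CC(C)=CCC/C(C)=C/CC/C(C)=C/CC[C@@H]1[C@@]2(C)C/C(=C\c3ccc(OCc4cn(-c5c(Cl)cc([N+](=O)[O-])cc5Cl)nn4)cc3)C(=O)C(C)(C)[C@@H]2CC[C@@]1(C)O` is not yet measured and differs from compound 3 by 2,6-dichloro-4-nitrophenyl in place of 3-chloro-4-fluorophenyl on an aromatic nitrogen, the same change as that from compound 1 to compound 2, made at the same place. Because the first step of a 1.1-fold higher number from compound 1 to compound 2 (0.06 log units; within the scatter) was small, the expected step of a 1.1-fold higher number from compound 3 to compound 4 (0.04 log units; within the scatter) is likewise small. In this assay compound 4 is therefore estimated at 47000 nM, between 25000 nM and 90000 nM.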

Compound 4, half-maximal inhibitory concentration: 36900 nM
Compound 4: middle estimate off by 1.3-fold (0.11 log units), on the high side; the range from low to high includes it.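

In this assay, putting 2,6-dichloro-4-nitrophenyl in place of 3-chloro-4-fluorophenyl gives a 1.2-fold lower number from compound 3 to compound 4 (0.07 log units; within the scatter). Set beside the same change on the core of compound 1, the two steps agree: the same change on two cores in this assay, a 1.1-fold higher number (0.06 log units; within the scatter) from compound 1 to compound 2 and a 1.2-fold lower number (0.07 log units; within the scatter) from compound 3 to compound 4, 1.3-fold (0.12 log units) apart, within the scatter of two such steps This shows that, for this one pair of aryl groups, the absence of a clear effect carries over between these two cores; it does not show that the change would stay this small on any other core, or that other aryl groups would behave alike.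

The compounds shown leave open whether an amine or a carboxylic acid on the phenyl ring would give a step beyond the scatter on either core. They also leave open what a methyl group in place of the aryl on the triazole would do.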